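Anilino-substituted series in the glioblastoma antiproliferation screen

A few compounds are considered here, and "the series" means these few. Any claim that something is new, unique, unknown or untested is made for them only; others in the source may bear on it.

Measured so far:
compound 1 `Cc1nc(SCC(=O)Nc2nc(-c3ccc(Cl)cc3)cs2)n(Nc2ccccc2)c1C` — 41400 nM
compound 2 `Cc1ccc(Nn2c(SCC(=O)Nc3nc(-c4ccccc4)cs3)nc(C)c2C)cc1` — > 100000 nM

Among the measured compounds shown here, compound 1 is the only member of the series with a numerical result in a functional assay on U-251 cells (Homo sapiens) for antiproliferative activity, read by sulforhodamine B assay, with a stated time of 48 h; a lower number here means that less compound is tolerated, a higher number that more compound is tolerated; compound 1 gives 41400 nM there. For compound 2 the value of > 100000 nM in this assay is a limit, not a number, at which one of the two results so far sits (the limit of > 100000 nM in this assay, at which 1 of the 2 values shown sits). Compound 2 differs from compound 1 in more than one place, so its limit is noted beside the number for compound 1 without being read as a step.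

Compound 3 `COc1ccc(Nn2c(SCC(=O)Nc3nc(-c4ccc(Cl)cc4)cs3)nc(C)c2C)cc1` has not yet been measured. It is compound 1 with methoxy in place of hydrogen on an aromatic carbon, on the aromatic carbon para to a large group. For the measured compounds named here, no measured pair isolates such a change. Given that compound 1 already gives 41400 nM in this assay, the expected step from compound 1 to compound 3 is a 1.3-fold higher number from compound 1 to compound 3 (0.12 log units; within the scatter), within the scatter or toward weaker activity rather than stronger. Compound 3 is estimated at 55000 nM in this assay, expected between 18000 nM and 100000 nM.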

Compound 3, concentration lethal to 50% of the cells: > 100000 nM
Compound 3 ended at the assay's limit (the forecaster's own chance of this, stated with the estimate: 40%); middle value at least 1.8-fold (0.25 log units) away from the limit.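

In this assay, among the compounds shown here, methoxy in place of hydrogen on the aromatic carbon para to a large group gives an at least 2.4-fold higher number from compound 1 to compound 3 (0.38 log units; beyond the scatter), the first step that isolates a change in one place. Going by these compounds, the result for compound 3, > 100000 nM, is a limit and not a number, so the true size of the step remains unknown. This position on the anilino ring is therefore sensitive to at least this one change, and compound 1 remains the only compound with a numerical result: the limit of > 100000 nM in this assay, at which 2 of the 3 values shown sit.

On these data alone, whether the shift is specific to methoxy or extends to other groups on the same aromatic carbon stays open; fluorine, hydroxyl or an amine there would test this on the core of compound 1. Compound 2 also carries a group on this ring, but it differs from compound 1 in more than one place, so it cannot settle the question, and the compounds shown say nothing about ethoxy or a longer alkoxy chain at this position.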